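A few compounds are considered here, and "the series" means these few. Any claim that something is new, unique, unknown or untested is made for them only; others in the source may bear on it.

Three measured compounds share one core. Compound 1 `N#CC1=C(N)Oc2nc(Nc3ccc(S(N)(=O)=O)cc3)sc2C1c1ccc([N+](=O)[O-])cc1` is the reference point; in a functional assay on HepG2 cells (Homo sapiens) for cytotoxicity, read by sulforhodamine B assay, with a stated time of 48 h (on this read-out lower numbers stand for stronger inhibition and higher numbers for weaker inhibition), compound 1 gives 60000 nM. Compound 2 `N#CC1=C(N)Oc2nc(Nc3ccc(S(N)(=O)=O)cc3)sc2C1c1cccc(Br)c1` gives 72000 nM in this assay. The difference between these two is small: a 1.2-fold higher number from compound 1 to compound 2 (0.08 log units; within the scatter). Compound 3 `N#CC1=C(N2C(=O)CCC2=O)Oc2nc(Nc3ccc(S(N)(=O)=O)cc3)sc2C1c1ccc([N+](=O)[O-])cc1` gives 45000 nM in this assay. Again the step is small: a 1.3-fold lower number from compound 1 to compound 3 (0.12 log units; within the scatter). Compound 3 therefore stands within the usual scatter of both compound 1 and compound 2, and on these numbers nothing separates the three compounds.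

Compound 4 `N#CC1=C(NC(=O)CCC(=O)O)Oc2nc(Nc3ccc(S(N)(=O)=O)cc3)sc2C1c1ccc([N+](=O)[O-])cc1` has not yet been measured. It differs from compound 3 in one place: ((2-carboxyethyl)carbonyl)amino in place of 2,5-dioxopyrrolidin-1-yl on a double-bonded ring carbon. Among the compounds with values here, only one measured step touches that same position, the step from compound 1 to compound 3, and it stayed within the scatter. The step from compound 1 to compound 2 alters a different position and also stayed within the scatter. No measured change on this core has moved the number beyond the scatter, so for compound 4 no step beyond the scatter is expected either, in either direction. For compound 4 the estimate in this assay is 45000 nM, with a range from 20000 nM to 100000 nM. This estimate means an expected step of no change at the digits printed from compound 3 to compound 4 (within the scatter).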

Compound 4, half-maximal inhibitory concentration: 32000 nM
Beside the measured number, compound 4's estimate is 1.4-fold (0.15 log units) above it; low and high end bracket the measured number.
By their numbers in this assay, from the lowest: compounds 4, 3, 1 and 2 (each within the scatter of the next, the first and the last beyond it).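

Replacing the 2,5-dioxopyrrolidin-1-yl group with ((2-carboxyethyl)carbonyl)amino swaps a closed ring with no hydrogen-bond donors for an open chain with two, yet this assay records only a 1.4-fold lower number from compound 3 to compound 4 (0.15 log units; within the scatter), which stays within the scatter. Adding the (2-carboxyethyl)carbonyl group to the amine nitrogen also stays within the scatter, at a 1.9-fold lower number from compound 1 to compound 4 (0.27 log units; within the scatter), so amino, the ring and the open chain ending in a carboxylic acid can no longer be told apart at this position on the double-bonded ring carbon. Nothing available here explains why such different groups give values this close.

On these data alone, it remains open whether a longer chain, a methyl ester in place of the carboxylic acid, or a small acetyl group on the amine nitrogen would move the number beyond the scatter. These three groups are also shown only on the core carrying 4-nitrophenyl, so it is unknown whether they would behave the same way with 3-bromophenyl on the saturated ring carbon.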